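The compounds below may be only part of what the source reports. "The series", "measured", "known", "first", "only" and "open" are said of these compounds alone.

Compound 1 (`O=C1/C(=C/c2cccnc2)CNC/C1=C\c1ccccc1F`) gives > 20000 nM in a functional assay on SMMC-7721 cells (Homo sapiens) for cytotoxicity, read by MTT assay, with a stated time of 24 h (a lower number here means a stronger inhibitor, a higher number a weaker inhibitor), and this value is a limit of the assay, not a number. Going by the values given here, compound 2 (`O=C1/C(=C/c2cccnc2)CNC/C1=C\c1ccccc1C(F)(F)F`) gives 5100 nM in this assay and holds the only exact number so far. Among the compounds with values here, the single measured step is an at least 3.9-fold lower number from compound 1 to compound 2 (0.59 log units; beyond the scatter) and it concerns a change on an aromatic carbon. Compound 3 (`O=C1/C(=C/c2cccnc2)CN(S(=O)(=O)c2ccc([N+](=O)[O-])cc2)C/C1=C\c1ccccc1C(F)(F)F`) has not yet been measured and carries (4-nitrophenyl)sulfonyl in place of hydrogen on an amine nitrogen in a ring. This change lies at a different place, so compound 2 and its step of an at least 3.9-fold lower number from compound 1 to compound 2 (0.59 log units; beyond the scatter) offer only a rough guide to size, and no measurement shows the direction. A step of similar modest size toward a lower number is therefore expected, estimated as a 2.6-fold lower number from compound 2 to compound 3 (0.41 log units; beyond the scatter) in this assay. Compound 3 is estimated at 2000 nM (range 500 nM to 9000 nM).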

Compound 3, half-maximal inhibitory concentration: 15900 nM
Compound 3: middle estimate off by 8.0-fold (0.90 log units), on the low side; measured number outside the range, above it.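

Going by these compounds alone, the amine nitrogen in the ring is a second place on the shared core, and the only step there runs the opposite way to the step on the aromatic carbon: in this assay, the change gives a 3.1-fold higher number from compound 2 to compound 3 (0.49 log units; beyond the scatter). So (4-nitrophenyl)sulfonyl on this nitrogen weakens the compound, although compound 3 still gives an exact number. Compound 1 remains the one compound at a limit of the assay, which is not a number, and it differs from compound 3 in two places, so the two cannot be compared: the limit of > 20000 nM in this assay, at which 1 of the 3 values shown sits.

A single compound cannot show which part of (4-nitrophenyl)sulfonyl goes with the higher number: the sulfonyl link, the aromatic ring or the nitro group. It also leaves open how this nitrogen responds to a small group such as methyl or acetyl, or to phenylsulfonyl without the nitro group.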